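This account rests on a few compounds, and the source may have more. Where it says the series, first, only, none or still open, it means among the compounds named here.

Of the compounds shown here, two of a shared core have been measured in an ADME assay on microsomes (Rattus norvegicus) for metabolic stability; a lower number here means that the compound disappears faster, a higher number that the compound lasts longer. Compound 1, `O=C1c2cc(-c3ccc(OC(F)(F)F)cc3)ccc2OCCN1Cc1ncccn1`, gives 3.33 h in this assay. Compound 2, `O=C1c2cc(-c3ccc(OC(F)(F)F)cc3)ccc2CCN1Cc1ncccn1`, gives 2.5 h in this assay. Compound 2 stands with the lowest of the two numbers, yet its nearest neighbour, compound 1, lies within the usual scatter of it, so the two values cannot be told apart.

The next compound, compound 3, `O=C1c2cc(-c3ccc(C(F)(F)F)cc3)ccc2CCN1Cc1ncccn1`, differs from compound 2 in one place: trifluoromethyl in place of trifluoromethoxy on an aromatic carbon. Among the measured compounds shown here, no step between measured compounds is known for this change, so nothing in the data so far tells how the half-life responds to it. Compound 3 is therefore expected to stay close to compound 2, with a step of a 1.1-fold higher number from compound 2 to compound 3 (0.05 log units; within the scatter) in this assay that is expected to be small, if anything slightly upward, and not beyond the scatter. For compound 3 the half-life in this assay is estimated at 2.8 h, with a range from 1.4 h to 5.6 h.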

Compound 3, half-life in the Rattus norvegicus assay: 5.9 h
Beside the measured number, compound 3's estimate is 2.1-fold (0.32 log units) below it; measured number above the stated range.
By their numbers in the Rattus norvegicus assay, from the lowest: compounds 2, 1 and 3 (each within the scatter of the next, the first and the last beyond it).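

Trifluoromethyl in place of trifluoromethoxy, on an aromatic carbon para to a large group, gives the first readable step at this position in the Rattus norvegicus assay: a 2.4-fold higher number from compound 2 to compound 3 (0.37 log units; beyond the scatter). The step is modest but beyond the scatter, so the half-life does respond to the group at this place, at least in this pair. The change does not act on one read-out alone, for in a physicochemical assay for solubility (on this read-out lower numbers stand for lower solubility and higher numbers for higher solubility), compound 2 gives 60000 nM and compound 3 gives 28000 nM, so the longer half-life comes here with a lower solubility: the measured solubility of compound 2, 60000 nM, and of compound 3, 28000 nM, a 2.1-fold lower number (0.33 log units; beyond the scatter)

On these data alone, all of this rests on a single pair, and whether the same change reads alike on the core of compound 1, which also carries trifluoromethoxy, stays open. Also open, as far as these compounds go, is how a nitrile, a chlorine atom or a methyl group at this same place would stand in the Rattus norvegicus assay and in the physicochemical assay, and whether any of them would keep the longer half-life of compound 3 without the lower solubility seen for it.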